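Trifluoromethyl in place of chloro on the fluorinated aryl group

The source may hold more compounds than are shown below. What is called first, only, known or untested is meant among the compounds shown, and "the series" means these compounds.

In an ADME assay on the whole organism (Rattus norvegicus, strain Sprague-Dawley) for pharmacokinetics, using cassette dosing, at a dose of 0.5 mg/kg by the intravenous route (on this read-out lower numbers stand for slow clearance and higher numbers for fast clearance), compound 1 (`O=C(Nc1ccc2[nH]c(=O)oc2c1)C(=O)N1CCN(c2ccc(C(F)(F)F)cc2)CC1`) gives 15.1 mL/min/kg, compound 2 (`O=C(Nc1ccc2[nH]c(=O)oc2c1)C(=O)N1CCN(c2ccc(F)c(F)c2)CC1`) gives 4 mL/min/kg and compound 3 (`O=C(Nc1ccc2[nH]c(=O)oc2c1)C(=O)N1CCN(c2ccc(Cl)c(F)c2)CC1`) gives 5.6 mL/min/kg. Compound 3 therefore sits level with compound 2, with a 1.4-fold higher number from compound 2 to compound 3 (0.15 log units; within the scatter), and well under compound 1. Compound 4 (`O=C(Nc1ccc2[nH]c(=O)oc2c1)C(=O)N1CCN(c2ccc(C(F)(F)F)c(F)c2)CC1`) carries trifluoromethyl in place of chloro on an aromatic carbon, ortho to a fluoro group: trifluoromethyl in place of chloro on an aromatic carbon. The nearest evidence is a 2.7-fold lower number from compound 1 to compound 3 (0.43 log units; beyond the scatter), read backwards, and a 3.8-fold lower number from compound 1 to compound 2 (0.58 log units; beyond the scatter) agrees in direction. Neither step isolates this change, since compound 1 lacks the fluoro group that compound 4 keeps. A partial reversal is expected, with an estimated rise of a 1.8-fold higher number from compound 3 to compound 4 (0.25 log units; within the scatter). For compound 4 the estimated clearance is 10 mL/min/kg, with an expected range of 5 mL/min/kg to 20 mL/min/kg.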

Compound 4, clearance: 5.6 mL/min/kg
Estimate against measurement, compound 4: 1.8-fold (0.25 log units) above, within the range that was stated.
By their numbers in this assay, from the lowest: compounds 2, 3 and 4 (each within the scatter of the next); then compound 1.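

On the position ortho to a fluoro group, trifluoromethyl and chloro give matching clearance in this assay (no change at the digits printed from compound 3 to compound 4 (within the scatter)), and fluoro at that place stays within the scatter of both (a 1.4-fold higher number from compound 2 to compound 4 (0.15 log units; within the scatter)). The fast clearance of compound 1 therefore does not follow from trifluoromethyl alone, since fluoro in place of hydrogen on the same aryl group gives a clear step (a 2.7-fold lower number from compound 1 to compound 4 (0.43 log units; beyond the scatter)). No measurement available here bears on the reason for this step.

On these data alone, it remains open whether a nitrile or a methoxy group at this place would stay level with these halogen-bearing groups. As far as these compounds go, whether the fluoro step also holds with chloro as the partner group also remains open.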